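Adding a chloro group to the most active urea

The source may report more compounds than this note shows. Statements on the series, on what has been measured and on what is new or still open speak of the compounds shown alone.

Three compounds share one core and differ only in the group on the outer ring of the urea. Compound 1 `COc1cc2cc(Oc3ccc(NC(=O)Nc4ccccc4)cc3)c(C)nc2cc1OC` carries an unsubstituted ring, compound 2 `COc1cc2cc(Oc3ccc(NC(=O)Nc4ccc(C)cc4)cc3)c(C)nc2cc1OC` a methyl, and compound 3 `COc1cc2cc(Oc3ccc(NC(=O)Nc4cccc(C(F)(F)F)c4)cc3)c(C)nc2cc1OC` a trifluoromethyl. In a functional assay on SK-OV-3 cells (Homo sapiens) for inhibition, read by sulforhodamine B assay, with a stated time of 48 h, tested at 10 uM (on this read-out higher numbers stand for a weaker effect at the one concentration tested and lower numbers for a stronger effect), compound 1 gives 48.4%, compound 2 gives 87.8%, and compound 3 gives 3.35%. Compound 3 thus stands lowest of the three, which here means the strongest effect, and its nearest neighbour on the numbers is compound 1.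

Compound 4 `COc1cc2cc(Oc3ccc(NC(=O)Nc4ccc(Cl)c(C(F)(F)F)c4)cc3)c(C)nc2cc1OC` adds one more group to compound 3: chloro in place of hydrogen on an aromatic carbon.

For the measured compounds named here, no measured step adds a chloro group, so none bears on the change directly. The steps that do exist concern other groups on this ring: a number 39.4 percentage points higher from compound 1 to compound 2 (beyond the scatter) and a number 45.1 percentage points lower from compound 1 to compound 3 (beyond the scatter), with a number 84.5 percentage points lower from compound 2 to compound 3 (beyond the scatter) linking the two substituted compounds. These show that a single group on this ring can move the read-out a great deal in either direction, but they say nothing about a chloro entering beside a trifluoromethyl group. Since compound 3 already sits close to the floor of the scale, the step of a number 0.7 percentage points higher from compound 3 to compound 4 (within the scatter) is expected to stay within the scatter. Compound 4 is therefore estimated at 4%, within a range from -5% to 20%.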

Compound 4, a percentage reported as activity, at one concentration (the size of the read-out at that concentration, not a potency): -4.09%
Beside the measured number, compound 4's estimate is 8.1 percentage points above it; measured number inside the range.
By their numbers in this assay, from the lowest: compounds 4 and 3 (each within the scatter of the next); then compound 1; then compound 2.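

Chloro in place of hydrogen, ortho to the trifluoromethyl group, gives a number 7.4 percentage points lower from compound 3 to compound 4 (within the scatter) in this assay, so at this place the added atom brings no change that can be told apart from the scatter. For the compounds shown here, the earlier compounds showed only that one group on this ring can move the read-out a long way, whereas here a second group leaves it where it was, and the large distance to the other two ureas remains, with a number 91.9 percentage points lower from compound 2 to compound 4 (beyond the scatter) and a number 52.5 percentage points lower from compound 1 to compound 4 (beyond the scatter) on the same read-out. No measured evidence comes with these numbers to explain the result.

From the compounds shown here alone, compound 3 and compound 4 both read near the bottom of the scale at the one concentration tested, so any difference between them at lower concentrations remains unknown. Also open, going by these compounds, is whether a fluoro, a methoxy or an amine at this place would behave as the chloro does, and what a chloro would do alone on the unsubstituted ring of compound 1, without the trifluoromethyl group.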